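Ethyl to isopropyl on the amino side chain of compound 2

The compounds below may be only part of what the source reports. "The series", "measured", "known", "first", "only" and "open" are said of these compounds alone.

Measured compounds:
compound 1, `CCCNc1nc(Nc2ccc(C#N)cc2)nc(Oc2cccc3ccccc23)n1` — 29500 nM
compound 2, `CCNc1nc(Nc2ccc(C#N)cc2)nc(Oc2ccc3cc(Br)ccc3c2Br)n1` — 74400 nM

In an ADME assay on MT4 cells (Homo sapiens) for cytotoxicity, read by MTT assay, with a stated time of 4 days (on this read-out higher numbers stand for lower toxicity in this test and lower numbers for higher toxicity in this test), compound 2 gives 74400 nM, the higher of the two numbers measured. In this assay compound 1 gives 29500 nM, a lower number, and the difference between the two lies beyond the scatter of repeated measurements. Among the measured compounds shown here, no single-point step between the two is available, since they differ both in the side chain and in the substitution of the aryloxy ring, so the pair says only what the two values show.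

Compound 3, `CC(C)Nc1nc(Nc2ccc(C#N)cc2)nc(Oc2ccc3cc(Br)ccc3c2Br)n1`, differs from compound 2 in one place: methyl in place of hydrogen on a saturated chain carbon bound to a nitrogen on an aromatic ring and a saturated chain carbon. Taken one bond further out, this reads as ethyl to isopropyl, or ethylamino to isopropylamino. For the measured compounds named here, no measured pair in this set follows such a change, so nothing here tells how this assay responds to it. The change is small, a single carbon added to a short chain, and compound 3 is expected to remain close to compound 2, with a step of a 1.2-fold lower number from compound 2 to compound 3 (0.09 log units; within the scatter) that stays within the scatter. Compound 3 is therefore estimated at 60000 nM in this assay, within a range of 25000 nM to 150000 nM.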

Compound 3, half-maximal cytotoxic concentration: >= 209000 nM
Compound 3: only a limit was reported; the forecaster's own chance of this, stated with the estimate: 25%; middle value at least 3.4-fold (0.54 log units) from the limit.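

Among the compounds shown here, the earlier compounds offered no single-point step, so this is the first reading of a change at this place in this assay: methyl in place of hydrogen on the saturated chain carbon bound to the nitrogen, or ethylamino to isopropylamino, gives an at least 2.8-fold higher number from compound 2 to compound 3 (0.44 log units; beyond the scatter). Since higher numbers here stand for lower toxicity in this test, the entering methyl, with its 1 carbon, moves compound 3 towards lower toxicity in this test, and this single change carries the read-out beyond the scatter. Compound 3 is reported only as a limit of the assay, so the step gives a smallest size and no exact one: the limit of >= 209000 nM in this assay, at which 1 of the 3 values shown sits.

The compounds shown leave open how the read-out would respond to other groups on this nitrogen, such as a longer chain like butyl, a branched tert-butyl or a cyclopropyl ring. They also leave open whether ethylamino to isopropylamino would give a step of the same direction with the aryloxy group of compound 1 in place of the dibrominated one.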